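Cytotoxicity notes: ester variation from compound 3 to compound 4

This account rests on a few compounds, and the source may have more. Where it says the series, first, only, none or still open, it means among the compounds named here.

Three compounds of the series carry results in an ADME assay on HepG2 2.2.15 cells (Homo sapiens) for cytotoxicity; a lower number here means that less compound is tolerated, a higher number that more compound is tolerated. Compound 1 `C=CCn1c(=O)c(CCO)c(-c2ccccc2Cl)c2cc(Cl)ccc21` gives 23000 nM. Compound 2 `O=c1c(CCO)c(-c2ccccc2Cl)c2cc(Cl)ccc2n1-c1c(F)cccc1F` reaches only a limit of the assay, > 2300000 nM (the limit of > 2300000 nM in this assay, at which 1 of the 3 values shown sits). Compound 3 `CCOCC(=O)OCCc1c(-c2ccccc2Cl)c2cc(Cl)ccc2[nH]c1=O` gives 130000 nM, the highest of the two actual numbers, with compound 1 nearest. Within the data shown here, the only single-point step recorded, an at least 100-fold higher number from compound 1 to compound 2 (2.00 log units; beyond the scatter), is large. Compound 4 `COc1ccccc1/C=C/C(=O)OCCc1c(-c2ccccc2Cl)c2cc(Cl)ccc2[nH]c1=O` alters compound 3 on a carbonyl carbon instead: 2-(2-methoxyphenyl)ethenyl in place of ethoxymethyl on a carbonyl carbon. Among the measured compounds shown here, no recorded step touches that position, so the step from compound 1 to compound 2 offers no guide to the size of this one. The expected step is a 1.6-fold lower number from compound 3 to compound 4 (0.21 log units; within the scatter), a modest move toward a lower number. Compound 4 is therefore estimated at 80000 nM, between 25000 nM and 250000 nM.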

Compound 4, half-maximal cytotoxic concentration: 770000 nM
For compound 4 the middle estimate is 9.6-fold (0.98 log units) below the measured one; the whole stated range lies below it.
By their numbers in this assay, from the lowest: compound 1; then compound 3; then compound 4. At a limit, above all of these: compound 2.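

The carbonyl carbon of the ester is a second place where the number responds in this assay: 2-(2-methoxyphenyl)ethenyl in place of ethoxymethyl gives a 5.9-fold higher number from compound 3 to compound 4 (0.77 log units; beyond the scatter). So the series is not sensitive only at the aromatic nitrogen, and a larger group carrying an aromatic ring goes with more compound tolerated here. No measured property at hand accounts for this step.

Still open, as far as these compounds go, is whether the aromatic ring or the double bond carries the step, as the two enter together. Also open, from the compounds shown here alone, is how a plain phenyl or an amine-bearing chain would read at this carbonyl carbon.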